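Swapping Cyclopropyl for Isopropyl: Cytotoxicity Across Two Cores

A few compounds are considered here, and "the series" means these few. Any claim that something is new, unique, unknown or untested is made for them only; others in the source may bear on it.

Measured compounds:
compound 1 `CNC(=O)c1cc(Oc2ccc3c(C)c(-c4noc(C5CC5)n4)sc3c2)ccn1` — 6800 nM
compound 2 `CNC(=O)c1cc(Oc2ccc3c(C)c(-c4noc(C(C)C)n4)sc3c2)ccn1` — 5500 nM
compound 3 `CNC(=O)c1cc(Oc2ccc(-c3noc(C4CC4)n3)cc2C)ccn1` — 20000 nM

Of the compounds shown here, three have so far been tested in an ADME assay on H1-HeLa cells (Homo sapiens) for cytotoxicity, read by MTT assay, with a stated time of 3 days; on this read-out higher numbers stand for lower toxicity in this test and lower numbers for higher toxicity in this test. Compound 1 and compound 2 are built on one shared core, while compound 3 sits on a different core; the difference between the two cores is not broken down here. In this assay compound 3 gives 20000 nM, the highest of the three numbers. Its nearest neighbour is compound 1 at 6800 nM, and the furthest is compound 2 at 5500 nM; both of these gaps lie beyond the usual scatter of the measurement.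

Within the first pair, the only structural change is isopropyl in place of cyclopropyl on an aromatic carbon. That change made a 1.2-fold lower number from compound 1 to compound 2 (0.09 log units; within the scatter), a step too small to count as a real difference. Exactly the same change, at the same place on the five-membered ring, turns compound 3 into compound 4 `CNC(=O)c1cc(Oc2ccc(-c3noc(C(C)C)n3)cc2C)ccn1`, which has not yet been measured: isopropyl in place of cyclopropyl on an aromatic carbon.

Going by the values given here, with only one measured example of this change, the expectation for compound 4 rests on that single step. Since a 1.2-fold lower number from compound 1 to compound 2 (0.09 log units; within the scatter) stayed within the scatter, the step expected from compound 3 to compound 4 is likewise small, a 1.2-fold lower number from compound 3 to compound 4 (0.07 log units; within the scatter). Compound 4 is therefore expected to give about 17000 nM in this assay. Its lower end is estimated at 9000 nM. Its upper end is estimated at 35000 nM.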

Compound 4, half-maximal cytotoxic concentration: 8900 nM
Estimate against measurement, compound 4: 1.9-fold (0.28 log units) above, outside the stated range (below it).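

In this assay, putting isopropyl in place of cyclopropyl on the core of compound 3 gives a 2.2-fold lower number from compound 3 to compound 4 (0.35 log units; beyond the scatter), a modest step but one large enough to stand out from the usual scatter of the measurement. Set beside the earlier step on the other core, this result does not show that the core changes the outcome, since the two steps cannot be told apart: the same change on two cores in this assay, a 1.2-fold lower number (0.09 log units; within the scatter) from compound 1 to compound 2 and a 2.2-fold lower number (0.35 log units; beyond the scatter) from compound 3 to compound 4, 1.8-fold (0.26 log units) apart, within the scatter of two such steps. The change can therefore be carried from one core to the other with no measurable difference in step size, but this does not prove that the two steps are truly equal, and a single pair of steps sets no rule for the series, especially as only the newer step lies beyond the scatter.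

The compounds shown carry only cyclopropyl or isopropyl at this place on the five-membered ring, which leaves open how a longer chain such as n-butyl, an amine or a carboxylic acid there would read in this assay. Also open, on these data alone, is whether the swap from cyclopropyl to isopropyl would give a similar step on a third core, which would be a stronger test of how well it carries over.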